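A few compounds are considered here, and "the series" means these few. Any claim that something is new, unique, unknown or untested is made for them only; others in the source may bear on it.

Measured so far in a physicochemical assay for lipophilicity; on this read-out lower numbers stand for lower lipophilicity and higher numbers for higher lipophilicity
- compound 1 (`COc1cc(O)c(C(=O)/C=C/c2cc(OC)c(OC)c(OC)c2)cc1OC`): 3.5
- compound 2 (`COc1ccc(O)c(C(=O)/C=C/c2cc(OC)c(OC)c(OC)c2)c1`): 3.47
- compound 3 (`COc1ccc(C(=O)/C=C/c2c(OC)cccc2OC)c(O)c1`): 3.51

All three values lie within the usual scatter of one another, so compound 1 holds no distinct rank in this small set.

The next compound for this assay is compound 4 (`COc1ccc(C(=O)/C=C/c2cc(OC)c(OC)c(OC)c2)c(O)c1`). Relative to compound 1 the change is hydrogen in place of methoxy on an aromatic carbon, which is hydrogen in place of methoxy on an aromatic carbon, ortho to a methoxy group and para to a hydroxy group.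

Going by the values given here, only one measured step is of this kind: a number 0.03 log units lower from compound 1 to compound 2 (within the scatter). Among the compounds with values here, it removes a methoxy from the shared core, though not the one lost in compound 4, so no measurement covers this exact place. Within the data shown here, compound 3 provides no single-place step from compound 1.

With that one small step as the guide, no shift beyond the scatter is expected. The expected step is a number 0.03 log units lower from compound 1 to compound 4 (within the scatter), which stays within the scatter. Compound 4 is estimated at 3.47, with an expected range from 3.25 to 3.7.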

Compound 4, partition coefficient: 3.49
Estimate against measurement, compound 4: 0.02 log units below, and the stated range covers the measured number.
By their numbers in this assay, from the lowest: compounds 2, 4, 1 and 3 (each within the scatter of the next).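

Hydrogen in place of methoxy on this aromatic carbon, ortho to a methoxy group and para to a hydroxy group, now has its own reading in this assay: a number 0.01 log units lower from compound 1 to compound 4 (within the scatter). Alongside a number 0.03 log units lower from compound 1 to compound 2 (within the scatter), this gives two different places on the shared core where the same exchange has been read, and neither step leaves the scatter, so this read-out does not separate the two places. No evidence on the cause of this result is at hand.

Both steps replace methoxy with hydrogen, so they do not show how this assay would respond to an amine, a carboxylic acid or a longer chain at this place. On these data alone, the effect of removing both methoxy groups from these two places together also remains open.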